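Ethyl Ester of the Chlorophenyl Acid: An Expected Limit

The source may hold more compounds than are shown below. What is called first, only, known or untested is meant among the compounds shown, and "the series" means these compounds.

Of the compounds shown here, three have been measured. Compound 1 `O=C(O)c1cnc(-c2ccccc2F)[nH]c1=O` and compound 2 `O=C(O)c1cnc(-c2ccc(Cl)cc2)[nH]c1=O` are carboxylic acids on closely related cores; the difference between their two cores is not broken down here. In a functional assay on the whole organism (strain Sprague-Dawley) for inhibition, with Rattus norvegicus as the target, with a stated time of 10 min (on this read-out lower numbers stand for an effect already at smaller amounts and higher numbers for an effect only at larger amounts of compound), compound 1 gives 5 mg/kg. Compound 2 gives 5 mg/kg in this assay, level with compound 1 at the digits shown and within the scatter. Compound 3 `CCOC(=O)c1cnc(-c2ccccc2F)[nH]c1=O` differs from compound 1 by the change (ethyl in place of hydrogen on an oxygen next to a carbonyl group). In this assay compound 3 reaches only a limit, > 10 mg/kg, which is one of the values sitting at the limit of > 10 mg/kg in this assay, at which 1 of the 3 values shown sits. The step of an at least 2.0-fold higher number from compound 1 to compound 3 (0.30 log units; that floor lies within the scatter) is therefore known only as a floor.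

Compound 4 `CCOC(=O)c1cnc(-c2ccc(Cl)cc2)[nH]c1=O` is not yet measured; it stands to compound 2 as compound 3 stands to compound 1, with the same change (ethyl in place of hydrogen on an oxygen next to a carbonyl group). The step is expected to run a 3.0-fold higher number from compound 2 to compound 4 (0.48 log units; beyond the scatter), which rests on the level standing of compound 1 and compound 2 at 5 mg/kg and on the earlier step of an at least 2.0-fold higher number from compound 1 to compound 3 (0.30 log units; that floor lies within the scatter). Compound 4 is estimated at 15 mg/kg, between 7 mg/kg and 40 mg/kg, and most likely reported again only as a limit.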

Compound 4, dose for 50% inhibition: > 30 mg/kg
Compound 4: only a limit was reported (the forecaster's own chance of this, stated with the estimate: 75%); middle value at least 2.0-fold (0.30 log units) from the limit.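

In this assay compound 4 reaches only a limit, > 30 mg/kg. Going by these compounds, on the core of compound 2, ethyl in place of hydrogen on an oxygen next to a carbonyl group therefore gives an at least 6.0-fold higher number from compound 2 to compound 4 (0.77 log units; beyond the scatter), and this floor shows that the number rises on this core, while the true size of the step stays unknown. Both acids lose ground to their ethyl esters only as far as these limits show, so the series does not tell whether the change carries over with the same size from one core to the other: the same change on two cores in this assay, an at least 2.0-fold higher number (0.30 log units; that floor lies within the scatter) from compound 1 to compound 3 and an at least 6.0-fold higher number (0.77 log units; beyond the scatter) from compound 2 to compound 4; the limit leaves it open whether they differ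

On these data alone, how far each ester lies past its limit remains open, and so does whether a free carboxylic acid is what matters or whether another group in its place would read the same. A methyl ester, a longer chain on that oxygen or a primary amide in place of the acid would bear on this question in this assay.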